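A few compounds are considered here, and "the series" means these few. Any claim that something is new, unique, unknown or untested is made for them only; others in the source may bear on it.

Compound 1 `Cc1ccc(NC(=O)[C@H]2CN(C)C[C@@H]2c2ccc(/C=C/C(=O)Nc3ccccc3N)cc2)cc1` and compound 2 `Cc1cc(NC(=O)[C@H]2CN(C)C[C@@H]2c2ccc(/C=C/C(=O)Nc3ccccc3N)cc2)ccc1F` differ only in the ring on an amide-type nitrogen. In an in vitro ADME assay on microsomes from liver (Mus musculus) for pharmacokinetics, read by LC-MS, with a stated time of 10 min, tested at 1 uM (a lower number here means slower removal, a higher number faster removal of the compound), compound 1 gives 62 mL/min/kg, and compound 2 gives 62 mL/min/kg; the step of no change at the digits printed from compound 1 to compound 2 (within the scatter) lies within the scatter, so compound 2 stands level with compound 1. Compound 3 `CN1C[C@H](C(=O)Nc2ccc(Cl)cn2)[C@@H](c2ccc(/C=C/C(=O)Nc3ccccc3N)cc2)C1` carries 5-chloropyridin-2-yl in place of 4-fluoro-3-methylphenyl on an amide-type nitrogen. Among the measured compounds shown here, only that one measured step bears on this new change, and it showed nothing beyond the scatter, so a step of a 1.1-fold lower number from compound 2 to compound 3 (0.05 log units; within the scatter) that stays within the scatter is expected here as well. Compound 3 is accordingly estimated at 55 mL/min/kg, with a range from 28 mL/min/kg to 110 mL/min/kg.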

Compound 3, clearance: 31 mL/min/kg
For compound 3 the middle estimate is 1.8-fold (0.25 log units) above the measured one; the range from low to high includes it.
By their numbers in this assay, from the lowest: compounds 3, 1 and 2 (each within the scatter of the next).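

In this assay, this amide-type nitrogen now carries a ring with a hetero atom: 5-chloropyridin-2-yl replacing 4-fluoro-3-methylphenyl gives a 2.0-fold lower number from compound 2 to compound 3 (0.30 log units; within the scatter), and replacing 4-methylphenyl gives a 2.0-fold lower number from compound 1 to compound 3 (0.30 log units; within the scatter). Adding a ring nitrogen with its hydrogen-bond acceptor therefore leaves all three compounds within the scatter of one another. No measurement here explains these numbers. Going by these compounds, the ring nitrogen and chlorine entered together, so their separate contributions remain open. Also open, on these data alone, is what a ring bearing a carboxylic acid or an amine would give here.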